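The source may hold more compounds than are shown below. What is called first, only, known or untested is meant among the compounds shown, and "the series" means these compounds.

Compound 1, `Cc1cc(C)nc(NS(=O)(=O)c2ccc(N3C(=O)/C(=C/c4coc5ccccc5c4=O)N=C3c3ccccc3)cc2)n1`, is tested in a functional assay on A549 cells (Homo sapiens) for cytotoxicity, read by sulforhodamine B assay, with a stated time of 72 h (on this read-out lower numbers stand for stronger inhibition and higher numbers for weaker inhibition), where compound 1 gives 63200 nM. Among the two plain numbers available this is the higher one, yet compound 3, `Cc1cc(NS(=O)(=O)c2ccc(NCc3coc4ccccc4c3=O)cc2)no1`, gives 59700 nM in this assay, a value within the scatter of compound 1, so no order between the two can be claimed. Compound 2, `Cc1cc(NS(=O)(=O)c2ccc(NC3=NC(=O)/C(=C\c4coc5ccccc5c4=O)S3)cc2)no1`, returns only a limit in this assay, > 100000 nM, as one of the values shown (the limit of > 100000 nM in this assay, at which 1 of the 3 values shown sits). Compound 4, `O=C1/C(=C/c2coc3ccccc3c2=O)N=C(c2ccccc2)N1c1ccc(S(=O)(=O)Nc2ccccn2)cc1`, differs from compound 1 in one place: pyridin-2-yl in place of 4,6-dimethylpyrimidin-2-yl on a sulfonamide nitrogen. Within the data shown here, no measured pair isolates this change, so its size is uncertain; a step no larger than the usual scatter is expected in this assay. Compound 4 is therefore expected to give 60000 nM, probably between 25000 nM and 150000 nM. The expected step of a 1.1-fold lower number from compound 1 to compound 4 (0.02 log units; within the scatter) stays within the scatter.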

Compound 4, half-maximal inhibitory concentration: > 100000 nM
Compound 4: only a limit was reported; the forecaster's own chance of this, stated with the estimate: 30%; middle value at least 1.6-fold (0.22 log units) from the limit.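

In this assay, among these compounds, this is the first direct test of the group on the sulfonamide nitrogen: pyridin-2-yl in place of 4,6-dimethylpyrimidin-2-yl gives an at least 1.5-fold higher number from compound 1 to compound 4 (0.19 log units; that floor lies within the scatter). On these data alone, the result for compound 4 is a limit and not a number, so the true size of the step is unknown, and its floor does not separate the pair from the scatter. The upper end of the read-out now holds more limits than before: the limit of > 100000 nM in this assay, at which 2 of the 4 values shown sit.

Left open is whether a methyl or an acetyl group on this nitrogen would give a lower number than compound 1. As far as these compounds go, whether this change acts the same way on the other cores also remains open.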